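The source may report more compounds than this note shows. Statements on the series, on what has been measured and on what is new or still open speak of the compounds shown alone.

Working notes on the series. Among the measured compounds shown here, in a functional assay on HT-29 cells (Homo sapiens) for antiproliferative activity, read by sulforhodamine B assay, with a stated time of 48 h (on this read-out lower numbers stand for stronger inhibition and higher numbers for weaker inhibition), compound 1 `Cc1ccc(NS(=O)(=O)c2ccc(N3CCNC3=O)cc2)cc1` gives 480 nM, the lowest of the two numbers so far; compound 2 `O=C1NCCN1c1ccc(S(=O)(=O)Nc2ccc(OC(F)F)cc2)cc1`, the nearest, gives 650 nM in this assay. For the measured compounds named here, the only measured step, a 1.4-fold higher number from compound 1 to compound 2 (0.13 log units; within the scatter), concerns difluoromethoxy in place of methyl on an aromatic carbon. Compound 3 `Cc1ccccc1NS(=O)(=O)c1ccc(N2CCNC2=O)cc1` has not been measured in this assay. It differs from compound 1 in one place: 2-methylphenyl in place of 4-methylphenyl on a sulfonamide nitrogen. The two have the same atoms, joined differently. Going by the values given here, no measured step addresses a change of this kind; the single step in hand altered a different group and stayed within the scatter, which is all the series so far tells. The step of a 1.5-fold higher number from compound 1 to compound 3 (0.16 log units; within the scatter) is therefore expected to be small, with no direction claimed beyond the scatter. Compound 3 is estimated at 700 nM, with a range of 250 nM to 2000 nM.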

Compound 3, half-maximal inhibitory concentration: 200 nM
Compound 3: middle estimate off by 3.5-fold (0.54 log units), on the high side; the whole stated range lies above it.
By their numbers in this assay, from the lowest: compound 3; then compounds 1 and 2 (each within the scatter of the next).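

In this assay, among the compounds shown here, 2-methylphenyl in place of 4-methylphenyl on a sulfonamide nitrogen gives the first step beyond the scatter: a 2.4-fold lower number from compound 1 to compound 3 (0.38 log units; beyond the scatter). The step is modest, but it shows that this position responds to a change that adds and removes no atoms, whereas the earlier step, a 1.4-fold higher number from compound 1 to compound 2 (0.13 log units; within the scatter), stayed within the scatter and showed no such response. No measurement in hand bears on what lies behind the lower number of compound 3.

The compounds shown leave open whether the lower number depends on the methyl group itself or would also appear with a chlorine atom, a methoxy group or an amine in its place. They also leave open whether difluoromethoxy, carried as a 2-substituted phenyl on the sulfonamide nitrogen, would follow compound 3.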